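Exchanging chloro for cyano on the shared core

This account rests on a few compounds, and the source may have more. Where it says the series, first, only, none or still open, it means among the compounds named here.

Compound 1 `N#Cc1cnc(NC(=O)CCCOc2ccccc2)s1` gives 4000 nM
Compound 2 `O=C(CCCOc1cccc(C(F)(F)F)c1)Nc1ncc(Cl)s1` gives 2500 nM

In an ADME assay on HepG2 cells (Homo sapiens) for cytotoxicity, read by CellTiter-Glo, with a stated time of 48 h (a lower number here means that less compound is tolerated, a higher number that more compound is tolerated), compound 2 gives 2500 nM, and compound 1 gives 4000 nM. Going by the values given here, these two values lie within the usual scatter of each other, so compound 2 stands level with the only other compound measured so far.

Compound 3 `N#Cc1cnc(NC(=O)CCCOc2cccc(C(F)(F)F)c2)s1` comes from compound 2 by a single exchange, cyano in place of chloro on an aromatic carbon, next to the ring sulfur: cyano in place of chloro on an aromatic carbon. Among the compounds with values here, no measured pair shows this exchange alone, so there is no direct precedent for its size. The nearest evidence is compound 1, which also carries the 5-cyano-1,3-thiazol-2-yl group and gives 4000 nM. That value sits within the scatter of the value of compound 2, so no clear direction is expected. The a 1.3-fold higher number from compound 2 to compound 3 (0.11 log units; within the scatter) is therefore expected to stay within the scatter of this assay. For compound 3 the estimated value is 3200 nM, with an expected range from 1200 nM to 9000 nM.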

Compound 3, half-maximal cytotoxic concentration: 1500 nM
Compound 3: the middle estimate sits 2.1-fold (0.33 log units) above what was measured, and the stated range covers the measured number.
By their numbers in this assay, from the lowest: compounds 3, 2 and 1 (each within the scatter of the next, the first and the last beyond it).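

In this assay the exchange of chloro for cyano on an aromatic carbon, next to the ring sulfur, now has a direct pair: the study records a 1.7-fold lower number from compound 2 to compound 3 (0.22 log units; within the scatter), so with the trifluoromethyl group kept, the two groups cannot be told apart at this position. Going by these compounds alone, the same compound also gives the first step beyond the scatter that changes one place: with the 5-cyano-1,3-thiazol-2-yl group held fixed, trifluoromethyl in place of hydrogen on an aromatic carbon gives a 2.7-fold lower number from compound 1 to compound 3 (0.43 log units; beyond the scatter), a modest shift towards less compound being tolerated. Nothing at hand bears on what sets the size of either step.

Going by these compounds, whether trifluoromethyl in place of hydrogen gives a similar step with the 5-chloro-1,3-thiazol-2-yl group remains open, as each exchange rests on a single pair. Also open, on these data alone, is how this position would respond to a methyl group, an amine or a carboxylic acid, and how a longer chain between the carbonyl and the ether oxygen would read in this assay.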